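Replacing a branched chain with a ring-bearing group

This account rests on a few compounds, and the source may have more. Where it says the series, first, only, none or still open, it means among the compounds named here.

Of the compounds shown here, three sharing one core have been tested in a functional assay on the whole organism for antagonist activity, with Mus musculus as the target; on this read-out higher numbers stand for an effect only at larger amounts of compound and lower numbers for an effect already at smaller amounts. Compound 1, `CCCC(=O)NCC(=O)N(C)c1ccc(Cl)cc1C(=O)c1ccccc1Cl`, gives 0.98 mg/kg. Compound 2, `CCCCC(=O)NCC(=O)N(C)c1ccc(Cl)cc1C(=O)c1ccccc1Cl`, gives 1.3 mg/kg. Compound 3, `CC(C)C(=O)NCC(=O)N(C)c1ccc(Cl)cc1C(=O)c1ccccc1Cl`, gives 6 mg/kg, the highest of the three numbers; it differs from the others only in the group attached to the carbonyl carbon of the outer amide.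

Compound 4, `CN(C(=O)CNC(=O)CN1CCCCC1)c1ccc(Cl)cc1C(=O)c1ccccc1Cl`, carries (piperidin-1-yl)methyl in place of isopropyl on a carbonyl carbon. For the measured compounds named here, two measured steps touch this same carbonyl carbon: a 6.1-fold higher number from compound 1 to compound 3 (0.79 log units; beyond the scatter) and a 4.6-fold higher number from compound 2 to compound 3 (0.66 log units; beyond the scatter), both beyond the scatter, so the group here does shift the read-out, and the branched isopropyl has so far given the weakest effect. The step of a 1.3-fold higher number from compound 1 to compound 2 (0.12 log units; within the scatter) stays within the scatter. Going by the values given here, no measured compound carries a ring or a nitrogen in this position, so the new group lies outside what the data cover.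

Given that both chain groups on this carbon gave lower numbers than compound 3, a moderately lower number is expected for compound 4, with wide uncertainty: the estimate is 2.5 mg/kg, between 0.6 mg/kg and 10 mg/kg, meaning an expected step of a 2.4-fold lower number from compound 3 to compound 4 (0.38 log units; beyond the scatter).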

Compound 4, dose for half-maximal effect: 7.5 mg/kg
For compound 4 the middle estimate is 3.0-fold (0.48 log units) below the measured one; the range from low to high includes it.
By their numbers in this assay, from the lowest: compounds 1 and 2 (each within the scatter of the next); then compounds 3 and 4 (each within the scatter of the next).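

In this assay, putting (piperidin-1-yl)methyl in place of isopropyl on this carbonyl carbon brings a six-membered non-aromatic ring and a nitrogen into the position, yet the two compounds cannot be told apart, with a 1.3-fold higher number from compound 3 to compound 4 (0.10 log units; within the scatter). Measured against the unbranched chains, the new group gives a 5.8-fold higher number from compound 2 to compound 4 (0.76 log units; beyond the scatter) and a 7.7-fold higher number from compound 1 to compound 4 (0.88 log units; beyond the scatter), so among these four compounds only the propyl and butyl groups give the low numbers, while the branched chain and the ring-bearing group both sit clearly higher. Nothing in the available data speaks to the reason for this grouping.

The compounds shown cannot separate the contribution of the ring from that of its nitrogen: cyclohexylmethyl would keep the ring without the nitrogen, and diethylaminomethyl would keep the nitrogen without the ring. On these data alone, it also remains open whether a longer straight chain such as pentyl, or a small carbon ring such as cyclopropyl, would stay with compound 1 and compound 2 at the low end or join compound 3 and compound 4 at the high end.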